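A Drawn Configuration Is the Only Change in Compound 4

The source may hold more compounds than are shown below. What is called first, only, known or untested is meant among the compounds shown, and "the series" means these compounds.

In a functional assay on U-87MG ATCC cells (Homo sapiens) for cytotoxicity, read by MTT assay, with a stated time of 48 h (a higher number here means a weaker inhibitor, a lower number a stronger inhibitor), three compounds sharing one core have been measured so far. Compound 1 (`CC(=NNC(=S)Nc1ccccc1F)c1ccccn1`) gives 5 nM, compound 2 (`CC(=NNC(=S)Nc1ccccc1[N+](=O)[O-])c1ccccn1`) gives 4.3 nM and compound 3 (`CC(=NNC(=S)Nc1ccccc1)c1ccccn1`) gives 1.4 nM. Compound 2 therefore belongs to the higher pair of the three numbers. The nitro for fluoro exchange within that pair is a 1.2-fold lower number from compound 1 to compound 2 (0.07 log units; within the scatter), while removing the nitro group gives a 3.1-fold lower number from compound 2 to compound 3 (0.49 log units; beyond the scatter). Removing the fluoro group gives a similar a 3.6-fold lower number from compound 1 to compound 3 (0.55 log units; beyond the scatter).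

Compound 4 (`C/C(=N\NC(=S)Nc1ccccc1[N+](=O)[O-])c1ccccn1`) departs from compound 2 only in how it is drawn: the two compounds have the same atoms and bonds; at least one stereo element is drawn with a configuration in one of them and without one in the other: 1 of 1 stereo elements differ; a double bond is drawn without a configuration in compound 2 and E in compound 4. The data do not say which configuration compound 2 had when it was tested. Going by the values given here, none of the measured steps touches this double bond. All three exchange a group on an aromatic carbon, so they offer no direct measure of this change and only show how far the numbers have moved in this small set. With identical atoms and bonds, no step beyond the scatter is expected in this assay. The expected step is no change at the digits printed from compound 2 to compound 4 (within the scatter). Compound 4 is expected at 4.3 nM, with an estimated range of 2 nM to 9 nM.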

Compound 4, half-maximal inhibitory concentration: 4.3 nM
Compound 4: middle estimate and measured number agree at the digits printed; the measured number falls inside the stated range.
By their numbers in this assay, from the lowest: compound 3; then compounds 2, 4 and 1 (each within the scatter of the next).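

In this assay, going by these compounds alone, the reading no change at the digits printed from compound 2 to compound 4 (within the scatter) is the first in this set that concerns the double bond rather than a group on an aromatic carbon. It gives the nitro compound a number tied to a stated configuration, E, where compound 2 alone left the configuration of the tested material unspecified. The two entries therefore read as a single level for this structure and not as a structure-activity step, and the only difference the pair records lies in the drawing: the fact that one of compounds 2 and 4 is drawn with a defined configuration and the other without, at the place where they differ

The compounds shown leave open how a compound drawn with the Z configuration at this double bond would read, since compound 2 cannot stand in for it while its tested configuration remains unknown, and so whether the configuration of this double bond matters at all in this assay is unsettled. They also leave open how the number would respond if an amine or a methoxy group took the place of the nitro group on the aromatic carbon, or if a longer chain took the place of the methyl group on the double bond.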